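Compound 3: a larger group on an aromatic oxygen

A few compounds are considered here, and "the series" means these few. Any claim that something is new, unique, unknown or untested is made for them only; others in the source may bear on it.

Values measured so far in an ADME assay on HUVEC cells (Homo sapiens) for cytotoxicity, read by MTT assay, with a stated time of 24 h (a lower number here means a stronger inhibitor, a higher number a weaker inhibitor), are:
- compound 1 `COc1cc(C2Oc3cc(-c4oc5cc(O)cc(O)c5c(=O)c4OC)ccc3OC2CO)ccc1O` at 22500 nM
- compound 2 `COc1cc(O)c2c(=O)c(OC)c(-c3ccc4c(c3)OC(c3ccc(O)c(OC)c3)C(CO)O4)oc2c1` at 43100 nM

Compound 1 lies within the scatter of compound 2, so the pair sets no order. Compound 3 `COc1cc(C2Oc3cc(-c4oc5cc(O)cc(O)c5c(=O)c4OC(=O)c4cc(O)c(O)c(O)c4)ccc3OC2CO)ccc1O` has (3,4,5-trihydroxyphenyl)carbonyl in place of methyl on an oxygen on an aromatic ring and awaits measurement. Among the measured compounds shown here, the only measured step (a 1.9-fold higher number from compound 1 to compound 2 (0.28 log units; within the scatter)) is a different, single-methyl change and offers weak guidance. No direction is expected, and the expected step (a 1.1-fold lower number from compound 1 to compound 3 (0.05 log units; within the scatter)) stays within the scatter, with wide uncertainty. Compound 3 is estimated at 20000 nM in this assay (range 7000 nM to 55000 nM) on present evidence.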

Compound 3, half-maximal inhibitory concentration: 18900 nM
Compound 3: middle estimate off by 1.1-fold (0.02 log units), on the high side; the range from low to high includes it.
By their numbers in this assay, from the lowest: compounds 3, 1 and 2 (each within the scatter of the next, the first and the last beyond it).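

In this assay, (3,4,5-trihydroxyphenyl)carbonyl in place of methyl on an oxygen on an aromatic ring gives a 1.2-fold lower number from compound 1 to compound 3 (0.08 log units; within the scatter). This position therefore carries a far larger group, with a six-membered aromatic ring and hydrogen-bond donors, and the values of the two compounds cannot be told apart. No measurement at hand accounts for this result. From the compounds shown here alone, whether an amine, a carboxylic acid or a longer alkyl chain on this oxygen would also stay within the scatter remains open. Also open, going by these compounds, is whether a plain benzoyl group, without the three hydroxy groups, would behave the same way.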